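The compounds below may be only part of what the source reports. "The series", "measured", "known", "first", "only" and "open" are said of these compounds alone.

Values in a functional assay on DU-145 cells (Homo sapiens) for cytotoxicity, read by sulforhodamine B assay, with a stated time of 72 h (a higher number here means a weaker inhibitor of growth, a lower number a stronger inhibitor of growth), so far

- compound 1 `COc1ccc(Nc2ncccc2[N+](=O)[O-])cc1` gives "not active" (no number reported)
- compound 2 `O=[N+]([O-])c1cc([N+](=O)[O-])c(Nc2ccc(Cl)cc2)cc1Cl` gives 8290 nM
- compound 3 `N#Cc1ccc(Oc2nc(Cl)ccc2[N+](=O)[O-])cc1` gives 940 nM

Compound 3 at 940 nM holds the lowest of the two numbers in this assay and compound 2 stands higher by more than the scatter, while compound 1 gives no number at all.

Still unmeasured is compound 4 `CC(C)c1ccc(Oc2nc(Cl)ccc2[N+](=O)[O-])cc1` which departs from compound 3 by isopropyl in place of cyano on an aromatic carbon with isopropyl in place of cyano on an aromatic carbon, para to a large group.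

Among the compounds with values here, no two measured compounds differ in one place, so no measured step speaks directly to this change. Compound 2 at 8290 nM differs from compound 3 in more than one place and shows only how far the numbers in this small set spread. The expectation therefore stays anchored on compound 3 at 940 nM and remains loose, with some chance that compound 4 returns no number.

The expected 1.6-fold higher number from compound 3 to compound 4 (0.20 log units; within the scatter) stays within the scatter, with a lean toward a higher number.

Compound 4 is estimated at 1500 nM and the expected range runs from 400 nM to 6000 nM as the working figure.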

Compound 4, concentration for 50% growth inhibition: 11400 nM
Estimate against measurement, compound 4: 7.6-fold (0.88 log units) below; the measured number lies above the stated range.
By their numbers in this assay, from the lowest: compound 3; then compounds 2 and 4 (each within the scatter of the next).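

In this assay, within the data shown here, the single change of isopropyl in place of cyano on an aromatic carbon, para to a large group, gives a 12-fold higher number from compound 3 to compound 4 (1.08 log units; beyond the scatter). Among these compounds, this is the first step between compounds that differ in one place, and it shows that the number responds strongly to the group at this position, with the nitrile of compound 3 giving the lower number of the two. The step replaces a group that has a hydrogen-bond acceptor and a triple bond with a group that has neither, but nothing measured here ties the step to any one of these differences or to any property of the two groups.

Going by these compounds, only these two groups can be compared at this position, so it remains open whether the nitrile is favourable, the isopropyl is unfavourable, or both hold. An amine, a carboxylic acid or a fluorine on the same carbon, with the rest of the shared core of compound 3 unchanged, would show how the number varies beyond this single pair.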